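This account rests on a few compounds, and the source may have more. Where it says the series, first, only, none or still open, it means among the compounds named here.

Of the compounds shown here, three built on one shared core have been tested in a functional assay with Alpha-1B adrenergic receptor (Homo sapiens) as the target, read by calcium flux; a higher number here means a larger maximal response, a lower number a smaller maximal response. Compound 1 `CCn1ncnc1-c1ccccc1NCC1=NCCN1` reaches 94% in this assay. Compound 2 `Cc1ccc(-c2ccccc2NCC2=NCCN2)n1C` reaches 0%. Compound 3 `c1ccc(-c2cn[nH]c2)c(NCC2=NCCN2)c1` reaches 72%, the second highest of the three numbers: compound 1 stands higher by more than the usual scatter, and compound 2 stands lower, also by more than the scatter. Compound 4 `Cn1ccnc1-c1ccccc1NCC1=NCCN1` is still unmeasured. It differs from compound 3 by 1-methyl-1H-imidazol-2-yl in place of 1H-pyrazol-4-yl on an aromatic carbon. Among the measured compounds shown here, no step between two measured compounds exists to size this change. Compound 1 carries a related ring in the same place and gives 94%, which supports a high value. The expected step, a number 10 percentage points higher from compound 3 to compound 4 (within the scatter), is a modest rise, possibly within the scatter. Compound 4 is therefore estimated at 82%, with a likely range from 45% to 100%.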

Compound 4, largest response reached (reported as maximal response), in percent of the reference or control that the assay uses: 104%
Beside the measured number, compound 4's estimate is 22 percentage points below it, and the stated range ends below it.
By their numbers in this assay, from the lowest: compound 2; then compound 3; then compounds 1 and 4 (each within the scatter of the next).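

Placing 1-methyl-1H-imidazol-2-yl in place of 1H-pyrazol-4-yl on this aromatic carbon gives this assay a first sized step at this position: a number 32 percentage points higher from compound 3 to compound 4 (beyond the scatter). The maximal response therefore depends on which five-membered aromatic ring sits here, although both rings carry 2 hetero atoms. Nothing measured here explains why.

Still open, as far as these compounds go, is whether the methyl group matters on its own, which 1H-imidazol-2-yl would test. Also open, from the compounds shown here alone, is whether a non-ring group here, such as an amine or a carboxylic acid, would keep any response.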